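This account rests on a few compounds, and the source may have more. Where it says the series, first, only, none or still open, it means among the compounds named here.

Values in a functional assay on OVCAR-8 cells (Homo sapiens); a lower number here means a stronger inhibitor of growth, a higher number a weaker inhibitor of growth:
- compound 1 (`O=S(=O)(/C=C/c1ccccc1)Cc1ccc(Nc2ncnc3ccccc23)cc1`) gives > 100000 nM as a limit
- compound 2 (`O=S(=O)(/C=C/c1ccc(Cl)cc1)Cc1ccc(Nc2ncnc3ccccc23)cc1`) gives > 100000 nM as a limit
- compound 3 (`O=S(=O)(/C=C/c1ccc(C(F)(F)F)cc1F)Cc1ccc(Nc2ncnc3ccccc23)cc1`) gives 100000 nM as a number

Going by the values given here, compound 3 holds the only actual number so far. The other values stand at the limit of > 100000 nM in this assay, at which 2 of the 3 values shown sit, and give no figure to compare it with.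

The next change leads to compound 4 (`O=S(=O)(/C=C/c1ccc(C(F)(F)F)cc1F)Cc1ccc(Nc2ncnc3cc(Cl)ccc23)cc1`). The difference is chloro in place of hydrogen on an aromatic carbon and amounts to chloro in place of hydrogen on an aromatic carbon, with quinazolin-4-yl becoming 7-chloroquinazolin-4-yl.

Among the compounds with values here, the one measured step of the same kind is a step that the two limits leave unreadable from compound 1 to compound 2 and it places the chloro on a different ring. The other two measured steps are a number no higher from compound 1 to compound 3 (the limit leaves the size open) and a number no higher from compound 2 to compound 3 (the limit leaves the size open) and both concern the aromatic group on the double-bonded chain. None of the three has a readable size, and none alters the shared core, so the data offer no size to carry over to this change.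

In this assay no shift beyond the scatter is therefore expected, and the estimated step is a 1.7-fold lower number from compound 3 to compound 4 (0.22 log units; within the scatter) as a working figure. For compound 4 the expected value is 60000 nM with an estimated range from 10000 nM to 100000 nM as its bounds.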

Compound 4, concentration for 50% growth inhibition: > 100000 nM
Compound 4 was reported as a limit; the forecaster's own chance of this, stated with the estimate: 45%; middle value at least 1.6-fold (0.22 log units) from the limit.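

Replacing hydrogen by chloro to give the 7-chloroquinazolin-4-yl group is the first change shown on the shared core rather than on the aromatic group of the double-bonded chain, and in this assay it gives a number no lower from compound 3 to compound 4 (the limit leaves the size open). Going by these compounds alone, at this aromatic carbon, chloro therefore brings no stronger inhibition of growth than hydrogen in compound 3, which gives 100000 nM, still the only actual number. The size of the step cannot be read, and the series remains largely at one limit: the limit of > 100000 nM in this assay, at which 3 of the 4 values shown sit.

The compounds shown leave open whether a methoxy group or an amine on this aromatic carbon would give a lower number than compound 3. They also leave open whether chloro at this place would behave the same way with the phenyl or 4-chlorophenyl group on the double-bonded chain.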